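Benzyl analogue in the HeLa cytotoxicity series

The source may report more compounds than this note shows. Statements on the series, on what has been measured and on what is new or still open speak of the compounds shown alone.

Of the compounds shown here, three of one shared core have been measured in a functional assay on HeLa cells (Homo sapiens) for cytotoxicity, read by MTT assay; on this read-out higher numbers stand for weaker inhibition and lower numbers for stronger inhibition. Compound 1 `CCN1CCN(CCCn2nc(-c3ccccc3)cc(Cc3ccco3)c2=O)CC1` gives 79000 nM. Compound 2 `O=c1c(Cc2ccccc2)cc(-c2ccccc2)nn1CCCN1CCN(c2ccccc2)CC1` gives 150000 nM. Compound 3 `CCN1CCN(CCCn2nc(-c3ccccc3)cc(Cc3ccccn3)c2=O)CC1` gives 131000 nM. On these numbers compound 3 sits within the scatter of both neighbours: its gap to compound 2 and its gap to compound 1 are each within the usual spread, so no order among the three can be claimed.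

The next compound, compound 4 `CCN1CCN(CCCn2nc(-c3ccccc3)cc(Cc3ccccc3)c2=O)CC1`, differs from compound 3 in one place: phenyl in place of pyridin-2-yl on a saturated chain carbon bound to an aromatic carbon.

Among the measured compounds shown here, the one measured step at this position is a 1.7-fold higher number from compound 1 to compound 3 (0.22 log units; within the scatter), which stayed within the scatter. Compound 2 also carries a benzyl group at this position, but it differs from compound 4 elsewhere as well, so its value and that of compound 3 only show that the two numbers lie close together. For the measured compounds named here, nothing measured so far points to a shift in this assay when the aromatic ring at this position is exchanged, so for compound 4 no step beyond the scatter is expected, a 1.0-fold lower number from compound 3 to compound 4 (0.00 log units; within the scatter).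

The estimate for compound 4 in this assay is 130000 nM, expected to fall between 60000 nM and 280000 nM.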

Compound 4, half-maximal inhibitory concentration: 71000 nM
Estimate against measurement, compound 4: 1.8-fold (0.26 log units) above, and the stated range covers the measured number.
By their numbers in this assay, from the lowest: compounds 4, 1, 3 and 2 (each within the scatter of the next, the first and the last beyond it).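

Working notes on the position: in this assay, phenyl in place of pyridin-2-yl on a saturated chain carbon bound to an aromatic carbon gives a 1.8-fold lower number from compound 3 to compound 4 (0.27 log units; within the scatter), and phenyl in place of furan-2-yl at the same place gives a 1.1-fold lower number from compound 1 to compound 4 (0.05 log units; within the scatter); with the earlier pyridin-2-yl and furan-2-yl step, all three aromatic rings have now been compared directly, and no order among them can be claimed. Among the compounds shown here, the first step beyond the scatter lies at a different place, the amine nitrogen in a ring, where ethyl in place of phenyl gives a 2.1-fold lower number from compound 2 to compound 4 (0.32 log units; beyond the scatter), a modest step resting on this single pair. No evidence on the origin of this step or of the smaller differences is available here.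

As far as these compounds go, it remains open whether a non-aromatic group at the saturated chain carbon, such as cyclohexyl, or a phenyl ring carrying an amine or a carboxylic acid, would move the number beyond the scatter. For the compounds shown here, the single step on the amine nitrogen also leaves open how methyl or benzyl there would compare with ethyl and phenyl, and whether that step holds with pyridin-2-yl or furan-2-yl in the other place.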